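A few compounds are considered here, and "the series" means these few. Any claim that something is new, unique, unknown or untested is made for them only; others in the source may bear on it.

Of the compounds shown here, three built on one shared core have so far been measured in an assay on LtK cells with ATP-sensitive inward rectifier potassium channel 11 (Homo sapiens) as the target; on this read-out lower numbers stand for an effect already at smaller amounts and higher numbers for an effect only at larger amounts of compound. Compound 1 `O=C(Nc1c(C(O)(C(F)(F)F)C(F)(F)F)ccc2ccccc12)C1CC1` gives 751 nM. Compound 2 `O=C(Nc1ccc(Cl)cc1)Nc1c(C(O)(C(F)(F)F)C(F)(F)F)ccc2ccccc12` gives 276 nM. Compound 3 `O=C(Nc1c(C(O)(C(F)(F)F)C(F)(F)F)ccc2ccccc12)c1ccc(F)cc1` gives 70 nM, the lowest of the three numbers, with an 11-fold lower number from compound 1 to compound 3 (1.03 log units; beyond the scatter) and a 3.9-fold lower number from compound 2 to compound 3 (0.60 log units; beyond the scatter) both beyond the scatter. Compound 4 `O=C(Nc1c(C(O)(C(F)(F)F)C(F)(F)F)ccc2ccccc12)c1ccc(Cl)cc1` has not yet been measured; it differs from compound 3 by chloro in place of fluoro on an aromatic carbon. Within the data shown here, no measured step exchanges these two halogens at the same place. Among the measured compounds shown here, the steps seen so far, a 2.7-fold lower number from compound 1 to compound 2 (0.43 log units; beyond the scatter), an 11-fold lower number from compound 1 to compound 3 (1.03 log units; beyond the scatter) and a 3.9-fold lower number from compound 2 to compound 3 (0.60 log units; beyond the scatter), each swap the whole group on the carbonyl carbon, so they show only that the group carried by compound 3 gives the lowest number here. Replacing one halogen by another at the same place is a smaller change than any of those, and the expected step of a 1.2-fold lower number from compound 3 to compound 4 (0.07 log units; within the scatter) is therefore judged to stay within the scatter, in either direction. Compound 4 is estimated at 60 nM, with a likely range between 25 nM and 150 nM.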

Compound 4, half-maximal effective concentration: 570 nM
Compound 4: middle estimate off by 9.5-fold (0.98 log units), on the low side, and the stated range ends below it.
By their numbers in this assay, from the lowest: compound 3; then compound 2; then compounds 4 and 1 (each within the scatter of the next).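

In this assay, exchanging a single halogen on an aromatic carbon para to a large group is no minor edit: chloro in place of fluoro gives an 8.1-fold higher number from compound 3 to compound 4 (0.91 log units; beyond the scatter), so this position responds strongly to which halogen it carries. The advantage of compound 3 over the cyclopropyl amide therefore belongs to the 4-fluorophenyl group and not to any halogen-bearing phenyl ring, since 4-chlorophenyl in place of cyclopropyl gives only a 1.3-fold lower number from compound 1 to compound 4 (0.12 log units; within the scatter), and 4-chlorophenyl in place of (4-chlorophenyl)amino gives a 2.1-fold higher number from compound 2 to compound 4 (0.31 log units; beyond the scatter). Nothing available explains why the two halogens differ so much.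

Going by these compounds, whether hydrogen, methyl or bromo at this place would match compound 3 or compound 4 remains open, so it is unclear whether fluoro lowers the number or chloro raises it. On these data alone, it is also open whether the same exchange would matter as much in the urea series of compound 2.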